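Chloro addition on two related cores: compound 4 outlook

This account rests on a few compounds, and the source may have more. Where it says the series, first, only, none or still open, it means among the compounds named here.

Compounds 1 and 3 share the same atoms joined differently; the difference between the two cores is not broken down here. Compound 1 `Clc1ccc(N2CC[C@@H]3CN[C@@H]3C2)cn1` gives 24 nM in a functional assay on HEK293 cells for agonist activity at Neuronal acetylcholine receptor; alpha4/beta2 (Homo sapiens), read by FLIPR; on this read-out higher numbers stand for an effect only at larger amounts of compound and lower numbers for an effect already at smaller amounts. Compound 3 `Clc1ccc(N2C[C@@H]3CCNC[C@@H]32)cn1` gives 37.4 nM in this assay; the gap between compound 1 and compound 3 lies within the scatter, so no order between them is read. Compound 2 `Clc1cc(N2CC[C@@H]3CN[C@@H]3C2)cnc1Cl` carries the change chloro in place of hydrogen on an aromatic carbon relative to compound 1; in this assay compound 2 gives 82 nM, and the step is a 3.4-fold higher number from compound 1 to compound 2 (0.53 log units; beyond the scatter).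

Compound 4 `Clc1cc(N2C[C@@H]3CCNC[C@@H]32)cnc1Cl` is not yet measured. Relative to compound 3 it carries chloro in place of hydrogen on an aromatic carbon, the same change as from compound 1 to compound 2, at a place described in the same words. Among the four compounds this change occurs twice in all, once measured.

For compound 4 a step of about a 3.3-fold higher number from compound 3 to compound 4 (0.52 log units; beyond the scatter) in this assay is expected, resting on the one measured case, compound 1 to compound 2 with a 3.4-fold higher number from compound 1 to compound 2 (0.53 log units; beyond the scatter), applied to compound 3 at 37.4 nM. Within the data shown here, because a 3.4-fold higher number from compound 1 to compound 2 (0.53 log units; beyond the scatter) is the only instance, the range around the estimate is kept wide. Compound 4 is estimated at 125 nM in this assay, between 50 nM and 320 nM.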

Compound 4, half-maximal effective concentration: 271 nM
The estimate for compound 4 lay 2.2-fold (0.34 log units) below the measured number; measured number inside the range.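

In this assay, chloro in place of hydrogen on an aromatic carbon again goes with a higher number, a 7.2-fold higher number from compound 3 to compound 4 (0.86 log units; beyond the scatter), so the change runs the same way on both cores shown and a shift towards larger amounts of compound carries over from the core of compound 1 to the core of compound 3. This rests on two cases in a single read-out, covers these four compounds only and gives no rule for any further core, and it offers no explanation of why the change acts as it does. The larger size of the new step is not read as a real dependence on the core, although two steps cannot rule such a dependence out, and the size carried across is known only roughly: the same change on two cores in this assay, a 3.4-fold higher number (0.53 log units; beyond the scatter) from compound 1 to compound 2 and a 7.2-fold higher number (0.86 log units; beyond the scatter) from compound 3 to compound 4, 2.1-fold (0.33 log units) apart, within the scatter of two such steps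

Still open, from the compounds shown here alone, is whether this direction belongs to chloro itself or would also appear with fluoro, methyl, methoxy or nitrile on the same aromatic carbon, ortho to a chloro group. Also open, going by these compounds, is whether either core would respond in the same way to one of these groups in place of the chloro already present in compound 1 and compound 3.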